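This account rests on a few compounds, and the source may have more. Where it says the series, first, only, none or still open, it means among the compounds named here.

In a functional assay on PC-3 cells (Homo sapiens) for cytotoxicity, read by WST assay, with a stated time of 72 h (a lower number here means a stronger inhibitor, a higher number a weaker inhibitor), compound 1 `O=C1Nc2c(ccc(F)c2F)C1(c1ccccc1)c1ccc(O)cc1` gives 8.9 nM. Compound 2 `CCCC1(c2ccc(O)cc2)C(=O)Nc2c1ccc(F)c2F` gives > 1000 nM, which is a limit of the assay and not a number. For the measured compounds named here, of the two compounds measured so far, it therefore stands at the weak end. Compound 3 `O=C1Nc2c(ccc(F)c2F)C1(c1ccc(O)cc1)C1CCCCCCC1` keeps the shared core and alters one group: cyclooctyl in place of propyl on a saturated ring carbon. In words, cyclooctyl takes the place of propyl on a saturated ring carbon. Going by the values given here, only one measured step bears on this change, the exchange of phenyl for propyl on that same carbon, which gave an at least 110-fold higher number from compound 1 to compound 2 (2.05 log units; beyond the scatter). That large loss shows how much this group can matter in this assay. With a ring restored there, though not an aromatic one, a sizeable move to a lower number is expected, recovering part of that loss. The expected change is an at least 8.3-fold lower number from compound 2 to compound 3 (0.92 log units; beyond the scatter). For compound 3 the estimated value is 120 nM, within an expected range of 15 nM to 1000 nM.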

Compound 3, half-maximal inhibitory concentration: > 1000 nM
Compound 3: a limit, no number; the forecaster's own chance of this, stated with the estimate: 25%; middle value at least 8.3-fold (0.92 log units) away from the limit.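

In this assay, putting a ring back on the saturated ring carbon does not by itself recover the strength of the phenyl compound: cyclooctyl in place of phenyl gives an at least 110-fold higher number from compound 1 to compound 3 (2.05 log units; beyond the scatter). The earlier step showed only that propyl fails there, whereas this one shows that a large eight-membered non-aromatic ring of carbon only fails as well, leaving phenyl as the only group shown here that gives a measurable number. The step between compound 2 and compound 3 cannot be read, because both stand at a limit of the assay and not at a number: the limit of > 1000 nM in this assay, at which 2 of the 3 values shown sit.

Going by these compounds, how far compound 2 and compound 3 lie past that limit remains open. So does whether a cyclohexyl ring or a pyridine ring on this carbon would bring back a measurable number.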